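Compound 2 and the step to compound 3

The source may report more compounds than this note shows. Statements on the series, on what has been measured and on what is new or still open speak of the compounds shown alone.

Among the measured compounds shown here, in a functional assay on PCO3 cells (Homo sapiens) for cytotoxicity, read by sulforhodamine B assay (on this read-out lower numbers stand for stronger inhibition of growth and higher numbers for weaker inhibition of growth), compound 2 `CC1=CC[C@@H]([C@@](C)(O)CCCC(C)(C)NC(=S)NN)CC1` gives 26800 nM, the highest of the two numbers measured so far. For the measured compounds named here, its only neighbour is compound 1 `CC1=CC[C@@H]([C@@](C)(O)CCCC(C)(C)NC=S)CC1`, which in this assay gives 11000 nM; the step of a 2.4-fold higher number from compound 1 to compound 2 (0.39 log units; beyond the scatter) is modest but beyond the scatter. Compound 3 `CC1=CC[C@@H]([C@@](C)(O)CCCC(C)(C)NC(=S)N/N=C\c2ccccc2)CC1` is the next compound to be measured: a group of 8 heavy atoms (7 carbon, 1 nitrogen; one six-membered aromatic ring of carbon only) in place of one nitrogen atom, on an amide-type nitrogen. Going by the values given here, no measured step mirrors this change. Among the compounds with values here, the one step measured, a 2.4-fold higher number from compound 1 to compound 2 (0.39 log units; beyond the scatter), shows only that enlarging the group on the thiocarbonyl carbon of compound 1 raised the number modestly, and it bears on compound 3 loosely at best. With so little to go on, compound 3 is expected to land near or somewhat under its parent, an estimated step of a 1.8-fold lower number from compound 2 to compound 3 (0.25 log units; within the scatter). In this assay compound 3 is therefore estimated at 15000 nM, with a range from 4000 nM to 50000 nM.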

Compound 3, concentration for 50% growth inhibition: 8470 nM
For compound 3 the middle estimate is 1.8-fold (0.25 log units) above the measured one; measured number inside the range.
By their numbers in this assay, from the lowest: compounds 3 and 1 (each within the scatter of the next); then compound 2.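

In this assay, the group of 8 heavy atoms with its six-membered aromatic ring, placed on the amide-type nitrogen, reverses the rise that came with the amino group, giving a 3.2-fold lower number from compound 2 to compound 3 (0.50 log units; beyond the scatter). Set against the simpler compound, the whole addition on the thiocarbonyl carbon comes to a 1.3-fold lower number from compound 1 to compound 3 (0.11 log units; within the scatter), so among these three compounds the number does not climb with the size of the group: compound 2 stands highest, while compound 3, with the largest group, does not. Nothing available here explains why the numbers move this way.

Open, as far as these compounds go, is whether a chlorine or a methoxy group on the aromatic ring, or a pyridine ring in its place, would take the number lower. Also open, from the compounds shown here alone, is how a saturated benzyl group on the same nitrogen would compare with compound 3.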